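Shortening the Side Chain on Compound 2

The source may report more compounds than this note shows. Statements on the series, on what has been measured and on what is new or still open speak of the compounds shown alone.

Compound 1 `O=C1/C(=N/c2cccc(C(F)(F)F)c2)c2ccccc2N1c1ccccc1`: < 1 ug/mL (a limit of the assay)
Compound 2 `CCN(CC)CCCCOc1cccc(N2C(=O)/C(=N/c3cccc(C(F)(F)F)c3)c3ccccc32)c1`: 5 ug/mL

Among the compounds with values here, in a physicochemical assay for solubility, at pH 7.4 (a lower number here means a less soluble compound, a higher number a more soluble compound), compound 2 is the only one with a true number, 5 ug/mL. Compound 1 gives only a limit of the assay, < 1 ug/mL.

Compound 3 `CCN(CC)COc1cccc(N2C(=O)/C(=N/c3cccc(C(F)(F)F)c3)c3ccccc32)c1` keeps the shared core and the diethylamino group but has a shorter chain: diethylamino in place of 3-(diethylamino)propyl on a saturated chain carbon bound to an oxygen on an aromatic ring. Put another way, 4-(diethylamino)butoxy becomes (diethylamino)methoxy.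

Within the data shown here, one measured step bears on this change. Placing 4-(diethylamino)butoxy on an aromatic carbon in place of hydrogen gave an at least 5.0-fold higher number from compound 1 to compound 2 (0.69 log units; beyond the scatter). Going by these compounds, its true size stays open, as the limit of < 1 ug/mL in this assay, at which 1 of the 2 values shown sits, shows. Among the measured compounds shown here, no measured step varies the chain length, so this step is only a loose guide. Compound 3 still carries a (diethylamino)-bearing chain on the same aromatic carbon, so most of that gain is expected to remain, with no change beyond the scatter in this assay. The expected result is a 1.3-fold lower number from compound 2 to compound 3 (0.10 log units; within the scatter). For compound 3 the estimated solubility is 4 ug/mL, with an expected range from 1.5 ug/mL to 10 ug/mL.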

Compound 3, solubility: 48 ug/mL
Compound 3: the middle estimate sits 12-fold (1.08 log units) below what was measured; measured number outside the range, above it.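

In this assay, within the data shown here, the number turns out to depend on the length of the chain on this oxygen, which the earlier compounds could not show: changing 4-(diethylamino)butoxy to (diethylamino)methoxy gave a 9.6-fold higher number from compound 2 to compound 3 (0.98 log units; beyond the scatter). The shorter chain therefore did more than keep the gain seen with the longer one, and putting (diethylamino)methoxy on the aromatic carbon in place of hydrogen gave an at least 48-fold higher number from compound 1 to compound 3 (1.68 log units; beyond the scatter). The full size of that last step stays open, since compound 1 is known only through a limit: the limit of < 1 ug/mL in this assay, at which 1 of the 3 values shown sits.

Among these compounds, with only two chain lengths in hand, it remains open whether the number climbs steadily as the chain shortens or whether an intermediate chain such as 2-(diethylamino)ethoxy would break that trend. It is also unclear how much of the change belongs to the diethylamino group itself, a question that a morpholine at the chain end, or a plain methoxy with no amine at all, could help to separate.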